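The source may hold more compounds than are shown below. What is called first, only, known or untested is meant among the compounds shown, and "the series" means these compounds.

Compound 1 `COc1cc2c(Nc3ccc(C#N)cc3)ncnc2cc1OCCCN(C)C`: 45000 nM
Compound 2 `COc1cc2c(Nc3ccc(C#N)cc3)ncnc2cc1OCCCN1CCC(C)CC1`: 43100 nM
Compound 3 `CCN1CCN(CCCOc2cc3ncnc(Nc4ccc(C#N)cc4)c3cc2OC)CC1`: 29900 nM

These three compounds share one core and differ only in the amine sitting on a saturated chain carbon, three bonds along the chain from an oxygen on an aromatic ring. In a functional assay on MCF7 cells (Homo sapiens) for antiproliferative activity, read by MTT assay, with a stated time of 72 h (a higher number here means a weaker inhibitor, a lower number a stronger inhibitor), compound 1 gives the highest of the three numbers. Its nearest neighbour is compound 2, at a 1.0-fold lower number from compound 1 to compound 2 (0.02 log units; within the scatter), and the furthest is compound 3, at a 1.5-fold lower number from compound 1 to compound 3 (0.18 log units; within the scatter); both steps lie within the scatter, as does a 1.4-fold lower number from compound 2 to compound 3 (0.16 log units; within the scatter). Exchanging the amine for a cyclic one therefore did not move the numbers beyond the scatter of the assay.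

Compound 4 `COc1cc2c(Nc3ccc(C#N)cc3)ncnc2cc1OCCCN1CCN(c2ccncc2)CC1` carries the same core and chain with a larger group at the same place: 4-(pyridin-4-yl)piperazin-1-yl in place of dimethylamino on a saturated chain carbon, three bonds along the chain from an oxygen on an aromatic ring. The new group shares its six-membered non-aromatic ring with two hetero atoms with the amine of compound 3, but adds a six-membered aromatic ring with one hetero atom. Going by the values given here, no measured step covers such an addition; the measured steps, all within the scatter, only show that changing the amine at this place from dimethylamino to two different rings left the numbers flat. On that basis the step to compound 4 is expected to be a 1.3-fold lower number from compound 1 to compound 4 (0.11 log units; within the scatter). The estimate for compound 4 is 35000 nM, with a range from 12000 nM to 100000 nM.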

Compound 4, half-maximal inhibitory concentration: 22900 nM
Compound 4: middle estimate off by 1.5-fold (0.18 log units), on the high side; the measured number falls inside the stated range.
By their numbers in this assay, from the lowest: compounds 4, 3, 2 and 1 (each within the scatter of the next).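

Going by these compounds alone, compound 4 extends what the earlier compounds showed: they placed only small alkyl-bearing rings at this place on the chain, whereas here the piperazine also carries a six-membered aromatic ring with one hetero atom, and the number in this assay still does not leave the scatter (a 2.0-fold lower number from compound 1 to compound 4 (0.29 log units; within the scatter)) (a 1.9-fold lower number from compound 2 to compound 4 (0.27 log units; within the scatter)). Within the data shown here, the closest comparison is the one that changes a single substituent, pyridin-4-yl in place of ethyl on the ring nitrogen (a 1.3-fold lower number from compound 3 to compound 4 (0.12 log units; within the scatter)), and it too shows that the added aromatic ring does not set compound 4 apart from compound 3. Nothing available here explains why the numbers stay so flat across these amines, whether large or small.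

The compounds shown leave open whether any group at this place can move the number beyond the scatter, for instance a carboxylic acid or a primary amine at the end of the chain. Also open, on these data alone, is the effect of a longer chain, since all four compounds keep the same chain length and the same shared core.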